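The source may hold more compounds than are shown below. What is called first, only, known or untested is meant among the compounds shown, and "the series" means these compounds.

Of the compounds shown here, three sharing one core have been measured in a functional assay on PC-3 cells (Homo sapiens) for cytotoxicity, read by MTT assay, with a stated time of 48 h; a lower number here means a stronger inhibitor, a higher number a weaker inhibitor. Compound 1 `O=C(CCl)N1N=C(c2cc3ccccc3oc2=O)CC1c1ccccc1` gives 2980 nM, compound 2 `O=C(c1ccccc1Cl)N1N=C(c2cc3ccccc3oc2=O)CC1c1ccccc1` gives 6370 nM, and compound 3 `CC(C)(C)NCC(=O)N1N=C(c2cc3ccccc3oc2=O)CC1c1ccccc1` gives 16400 nM. Compound 3 thus stands at the highest number of the three: the steps are a 5.5-fold higher number from compound 1 to compound 3 (0.74 log units; beyond the scatter) and a 2.6-fold higher number from compound 2 to compound 3 (0.41 log units; beyond the scatter), while a 2.1-fold higher number from compound 1 to compound 2 (0.33 log units; beyond the scatter) separates the other two.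

Compound 4 `O=C(CN1CCC(O)CC1)N1N=C(c2cc3ccccc3oc2=O)CC1c1ccccc1` differs from compound 3 by 4-hydroxypiperidin-1-yl in place of (tert-butyl)amino on a saturated chain carbon bound to a carbonyl carbon. The step that bears most directly on it is the one at the same place, a 5.5-fold higher number from compound 1 to compound 3 (0.74 log units; beyond the scatter), where bringing in the (tert-butyl)amino group raised the number beyond the scatter. Within the data shown here, no measured step exchanges one amine for another at this carbon, so the effect of swapping (tert-butyl)amino for 4-hydroxypiperidin-1-yl is not anchored by the data. The step of a 1.1-fold lower number from compound 3 to compound 4 (0.04 log units; within the scatter) is expected to stay within the scatter, with no clear direction. Compound 4 is therefore estimated at 15000 nM in this assay, with a range from 6000 nM to 40000 nM.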

Compound 4, half-maximal inhibitory concentration: "not active" (no number reported)
The entry for compound 4 holds no number; there is nothing to compare the estimate with.
By their numbers in this assay, from the lowest: compound 1; then compound 2; then compound 3.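

Among these compounds, compound 4 is reported in this assay as "not active", without a number, so no step linking it to compound 1, compound 2 or compound 3 can be read. Nothing at hand accounts for this result. The compounds shown leave open how far compound 4 lies from compound 3 and how one amine compares with another on this saturated chain carbon.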